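The source may hold more compounds than are shown below. What is called first, only, known or untested is meant among the compounds shown, and "the series" means these compounds.

Measured so far:
- compound 1, `C=C(Br)C(=O)Nc1cccc(-c2cn3nc(-c4ccccc4)sc3n2)c1`: 960 nM
- compound 2, `COc1ccc(-c2nn3cc(-c4cccc(N)c4)nc3s2)cc1OC`: 14000 nM

In a functional assay on CCRF-CEM cells (Homo sapiens) for inhibition, read by cell counting, with a stated time of 3 days (a higher number here means a weaker inhibitor, a lower number a stronger inhibitor), compound 2 gives 14000 nM, the higher of the two numbers recorded; compound 1 gives 960 nM in this assay, and the gap between the two lies beyond the scatter. The two compounds differ in more than one place, so no single step can be read from them; only the two values themselves stand.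

Compound 3, `C=C(Br)C(=O)Nc1cccc(-c2cn3nc(-c4ccc(OC)c(OC)c4)sc3n2)c1`, is not yet measured in this assay. From compound 2 it is reached by one change: (1-bromoethenyl)carbonyl in place of hydrogen on a nitrogen on an aromatic ring. Compound 1 carries the same ((1-bromoethenyl)carbonyl)amino group on its core and sits at the lower of the two numbers, which is the only ground available for an expectation. Within the data shown here, no step with this change alone has been measured, so the expectation rests on that comparison only.

The step from compound 2 to compound 3 is expected to be downward and beyond the scatter, as a 9.3-fold lower number from compound 2 to compound 3 (0.97 log units; beyond the scatter). For compound 3 the estimate in this assay is 1500 nM, with a range from 400 nM to 6000 nM.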

Compound 3, half-maximal inhibitory concentration: 380 nM
The estimate for compound 3 lay 3.9-fold (0.60 log units) above the measured number; the measured number lies below the stated range.
By their numbers in this assay, from the lowest: compound 3; then compound 1; then compound 2.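

In this assay the nitrogen on the aromatic ring now has a clean read: (1-bromoethenyl)carbonyl in place of hydrogen gives a 37-fold lower number from compound 2 to compound 3 (1.57 log units; beyond the scatter) on an otherwise unchanged structure, a large step that the comparison of compound 1 with compound 2 could not separate from their difference at the phenyl group. The other end of the series also has its first read, with the ((1-bromoethenyl)carbonyl)amino group held constant: 3,4-dimethoxyphenyl in place of phenyl on an aromatic carbon gives a 2.5-fold lower number from compound 1 to compound 3 (0.40 log units; beyond the scatter), a modest step that still lies beyond the scatter, so in these compounds the change on the nitrogen is the larger of the two. No available measurement offers an explanation for either step.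

Still open, as far as these compounds go, is whether the bromine or the double bond matters for the large step, a question that a propanoyl, acetyl or plain acryloyl group on the same nitrogen would address. Also open, from the compounds shown here alone, is how far the phenyl step extends, for example to a phenyl carrying one methoxy group, a carboxylic acid or an amine.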